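Chloro for trifluoromethyl in the methoxy branch of the series

The source may hold more compounds than are shown below. What is called first, only, known or untested is meant among the compounds shown, and "the series" means these compounds.

Three ureas sharing one core have been run in a functional assay on DU-145 cells (Homo sapiens) for inhibition, read by sulforhodamine B assay, with a stated time of 48 h, tested at 0.1 uM; on this read-out lower numbers stand for a stronger effect and higher numbers for a weaker effect at the one concentration tested. Compound 1 `O=C(Nc1cccc(-n2cc(-c3ccncc3)c(-c3cc(O)cc(Cl)c3)n2)c1)Nc1ccc(Cl)c(C(F)(F)F)c1` gives 99% in this assay. Compound 2 `O=C(Nc1cccc(-n2cc(-c3ccncc3)c(-c3cc(O)cc(Cl)c3)n2)c1)Nc1ccc(Cl)c(Cl)c1` gives 104% in this assay. Compound 3 `COc1cc(Cl)cc(-c2nn(-c3cccc(NC(=O)Nc4ccc(Cl)c(C(F)(F)F)c4)c3)cc2-c2ccncc2)c1` gives 98% in this assay. All three numbers sit within the scatter of one another; compound 3 is the lowest of them on paper, but its gap to compound 1 and its gap to compound 2 are both within the scatter, so no ordering can be read from them.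

Compound 4 `COc1cc(Cl)cc(-c2nn(-c3cccc(NC(=O)Nc4ccc(Cl)c(Cl)c4)c3)cc2-c2ccncc2)c1` is not yet measured. It differs from compound 3 in one place: chloro in place of trifluoromethyl on an aromatic carbon.

Within the data shown here, one measured step bears directly on this change: the same exchange on the hydroxy analogue, a number 5 percentage points higher from compound 1 to compound 2 (within the scatter). The other step, a number 1 percentage points lower from compound 1 to compound 3 (within the scatter), shows that the methoxy-for-hydroxy change likewise moved nothing beyond the scatter. Both steps point to the same conclusion: within this set no single exchange of this kind has produced a change in this assay beyond the scatter.

Compound 4 is therefore expected to give about 102% in this assay, with a range from 91% to 113%. The step of a number 4 percentage points higher from compound 3 to compound 4 (within the scatter) is expected to stay within the scatter.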

Compound 4, a percentage reported as activity, at one concentration (the size of the read-out at that concentration, not a potency): 97%
The estimate for compound 4 lay 5 percentage points above the measured number, within the range that was stated.
By their numbers in this assay, from the lowest: compounds 4, 3, 1 and 2 (each within the scatter of the next).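

The chloro-for-trifluoromethyl exchange, until now read only on the hydroxy core, also gives a number 1 percentage points lower from compound 3 to compound 4 (within the scatter) in this assay on the methoxy core, so at this position the exchange has now been read on two cores and stays within the scatter on both: the same change on two cores in this assay, a number 5 percentage points higher (within the scatter) from compound 1 to compound 2 and a number 1 percentage points lower (within the scatter) from compound 3 to compound 4, 6 percentage points apart, within the scatter of two such steps

The methyl on the oxygen, previously read only with the 4-chloro-3-(trifluoromethyl)phenyl group in place, now also gives a number 7 percentage points lower from compound 2 to compound 4 (within the scatter) with the 3,4-dichlorophenyl group in place, and again the two readings agree within the scatter: the same change on two cores in this assay, a number 1 percentage points lower (within the scatter) from compound 1 to compound 3 and a number 7 percentage points lower (within the scatter) from compound 2 to compound 4, 6 percentage points apart, within the scatter of two such steps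

Taken together, the four compounds form a closed square of two changes, and in this read-out neither change shows any dependence on the other at the one concentration tested.

As far as these compounds go, it remains open whether a group of a different kind at this position, such as an amine, a carboxylic acid or a longer chain, would move the number beyond the scatter. A single concentration also gives no potency, so any difference among these four compounds that would appear only at other concentrations remains unknown.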